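This account rests on a few compounds, and the source may have more. Where it says the series, first, only, none or still open, it means among the compounds named here.

Compound 1 `CCC[C@]1(C(=O)N2CC[C@](c3ccc(C(F)(C(F)(F)F)C(F)(F)F)cc3)(S(=O)(=O)c3ccc(F)cc3)C2)CC[C@H](C(=O)O)CC1`: "not determined" (no result reported)
Compound 2 `O=C(O)[C@H]1CC[C@](F)(C(=O)N2CC[C@](c3ccc(C(F)(C(F)(F)F)C(F)(F)F)cc3)(S(=O)(=O)c3ccc(F)cc3)C2)CC1`: "not determined" (no result reported)
Compound 3 `O=C(C1CCS(=O)(=O)CC1)N1CC[C@](c2ccc(C(F)(C(F)(F)F)C(F)(F)F)cc2)(S(=O)(=O)c2ccc(F)cc2)C1`: 96%

For the measured compounds named here, in an ADME assay on microsomes from liver (Mus musculus) for metabolic stability, with a stated time of 10 min (on this read-out higher numbers stand for a more stable compound and lower numbers for a less stable compound), compound 3 gives 96%, the only number available, as no result was reported for compound 1 or compound 2. Compound 4 `CCC1(C(=O)N2CC[C@](c3ccc(C(F)(C(F)(F)F)C(F)(F)F)cc3)(S(=O)(=O)c3ccc(F)cc3)C2)CCS(=O)(=O)CC1` differs from compound 3 in one place: ethyl in place of hydrogen on a saturated ring carbon. In words, this is ethyl in place of hydrogen on a saturated ring carbon. Going by the values given here, no measured pair shows what such a change does in this assay, so any forecast is uncertain. With compound 3 at 96%, little room remains upward, so a small downward step is expected, a number 8 percentage points lower from compound 3 to compound 4 (within the scatter), possibly no larger than the usual scatter. Compound 4 is estimated at 88%, within an expected range of 70% to 99%.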

Compound 4, percent of the compound remaining: 0%
Compound 4: middle estimate off by 88 percentage points, on the high side, outside the stated range (below it).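

In this assay, the saturated ring carbon of the 1,1-dioxothian-4-yl group turns out to be far from a neutral place to change: ethyl in place of hydrogen gives a number 96 percentage points lower from compound 3 to compound 4 (beyond the scatter). The high stability of compound 3 therefore does not survive this single addition in compound 4. No data shown here explain the loss.

From the compounds shown here alone, whether a methyl, a hydroxyl or an amine on the same carbon would behave like ethyl remains open. So does whether the loss is specific to ethyl or follows any replacement of that hydrogen.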